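The source may report more compounds than this note shows. Statements on the series, on what has been measured and on what is new or still open speak of the compounds shown alone.

Of the compounds shown here, three built on one shared core have been read in a functional assay on HepG2 cells (Homo sapiens) for cytotoxicity, read by MTT assay, with a stated time of 24 h; a higher number here means a weaker inhibitor, a lower number a stronger inhibitor. Compound 1 `O=C1/C(=C/c2cccnc2)CNC/C1=C\c1ccccc1F` gives 21000 nM. Going by the values given here, compound 2 `O=C1/C(=C/c2cccnc2)CN(S(=O)(=O)c2ccc([N+](=O)[O-])cc2)C/C1=C\c1ccccc1F` carries (4-nitrophenyl)sulfonyl on the amine nitrogen in the ring and gives 12800 nM, a value within the usual scatter of the one for compound 1. Compound 3 `O=C1/C(=C/c2cccnc2)CNC/C1=C\c1ccccc1C(F)(F)F` gives 5020 nM, the lowest of the three numbers, with compound 2 nearest in value and compound 1 furthest. Among the compounds with values here, the one measured step, a 4.2-fold lower number from compound 1 to compound 3 (0.62 log units; beyond the scatter), is modest and comes with trifluoromethyl in place of fluoro on an aromatic carbon.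

Compound 4 `O=C1/C(=C/c2cccnc2)CN(S(=O)(=O)c2ccc([N+](=O)[O-])cc2)C/C1=C\c1ccccc1C(F)(F)F` keeps the trifluoromethyl of compound 3 and has (4-nitrophenyl)sulfonyl in place of hydrogen on an amine nitrogen in a ring. Within the data shown here, no measured step shows this change directly on a trifluoromethyl compound. The closest evidence is the pair of fluoro compounds, where compound 2 at 12800 nM and compound 1 at 21000 nM stay within the scatter of each other. A change beyond the scatter in this assay is therefore not expected, although a small drift to a lower number is possible. The expected step is a 1.4-fold lower number from compound 3 to compound 4 (0.16 log units; within the scatter). For compound 4 the estimated value is 3500 nM, with an expected range from 1500 nM to 8000 nM.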

Compound 4, half-maximal inhibitory concentration: 9370 nM
Compound 4: the middle estimate sits 2.7-fold (0.43 log units) below what was measured; the measured number lies above the stated range.
By their numbers in this assay, from the lowest: compounds 3, 4, 2 and 1 (each within the scatter of the next, the first and the last beyond it).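

In this assay, putting (4-nitrophenyl)sulfonyl in place of hydrogen on the amine nitrogen of a trifluoromethyl compound gives a 1.9-fold higher number from compound 3 to compound 4 (0.27 log units; within the scatter), so this position now tolerates the group on both aromatic substituents without a change beyond the scatter, as the values of compound 1 and compound 2 had suggested for fluoro alone. The result also gives the second reading of the aromatic change, this time with the sulfonyl group in place: a 1.4-fold lower number from compound 2 to compound 4 (0.14 log units; within the scatter). The advantage of trifluoromethyl over fluoro seen on the free amine is therefore not a fixed increment, since the same change differs in size between the two cores: the same change on two cores in this assay, a 4.2-fold lower number (0.62 log units; beyond the scatter) from compound 1 to compound 3 and a 1.4-fold lower number (0.14 log units; within the scatter) from compound 2 to compound 4, 3.1-fold (0.49 log units) apart, beyond the scatter of two such steps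

Going by these compounds, the four compounds cover only hydrogen and (4-nitrophenyl)sulfonyl on this nitrogen, so it remains open whether a plain benzyl or acetyl group, or a sulfonyl group bearing an aminophenyl or methyl in place of the nitrophenyl, would move the number beyond the scatter. They also leave open whether the smaller aromatic step on the sulfonyl core would hold for a chloro or methoxy group on that aromatic ring.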